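The compounds below may be only part of what the source reports. "The series", "measured", "known", "first", "only" and "open" are said of these compounds alone.

Measured so far:
Compound 1, `CC(C)(C)c1ccc(OC(=O)c2cn(-c3ccccc3)nc2-c2cccnc2)cc1`: > 100000 nM
Compound 2, `CC(C)c1cccc(OC(=O)c2cn(-c3ccccc3)nc2-c2ccncc2)c1`: > 100000 nM

In a functional assay on MDA-MB-231 cells (Homo sapiens) for cytotoxicity, read by MTT assay, with a stated time of 48 h (a lower number here means a stronger inhibitor, a higher number a weaker inhibitor), compound 1 gives > 100000 nM, which is a limit of the assay and not a measured number. In this assay compound 2 gives > 100000 nM, likewise a limit rather than a number. Compound 2 therefore stands at the limit of > 100000 nM in this assay, at which 2 of the 2 values shown sit, so no real value is known for it, only that it falls beyond what this assay can read.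

Compound 3, `CC(C)(C)c1ccc(OC(=O)c2cn(-c3ccccc3)nc2-c2ccncc2)cc1`, has not yet been measured in this assay. It differs from compound 2 in one place: 4-(tert-butyl)phenyl in place of 3-isopropylphenyl on an oxygen next to a carbonyl group. Among the measured compounds shown here, no measured pair in this set shows what a change of this kind does in this assay, so no step beyond the usual scatter can be predicted in either direction. Since compound 2 sits at the limit, compound 3 is expected to sit there as well: an estimate of 150000 nM, with a range from 30000 nM to 600000 nM. The expected step is a step that the limit leaves unreadable from compound 2 to compound 3.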

Compound 3, half-maximal inhibitory concentration: 34500 nM
Compound 3: the middle estimate sits 4.3-fold (0.64 log units) above what was measured, and the stated range covers the measured number.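

In this assay, 4-(tert-butyl)phenyl in place of 3-isopropylphenyl on an oxygen next to a carbonyl group gives an at least 2.8-fold lower number from compound 2 to compound 3 (0.46 log units; beyond the scatter). With 4-(tert-butyl)phenyl held fixed, pyridin-4-yl in place of pyridin-3-yl on an aromatic carbon gives an at least 2.8-fold lower number from compound 1 to compound 3 (0.46 log units; beyond the scatter), so a change in either of these two places is enough to bring a compound within the readable range, and compound 3 alone carries a real number. The true size of each step stays unknown because each starting compound has only a limit: the limit of > 100000 nM in this assay, at which 2 of the 3 values shown sit.

From the compounds shown here alone, how much lower the number can go at either place remains open, since two of the three compounds give no real value to compare. Also open, going by these compounds, is what a carboxylic acid or an amine on the phenyl ring of compound 3 would do in this assay.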